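This account rests on a few compounds, and the source may have more. Where it says the series, first, only, none or still open, it means among the compounds named here.

Working notes on the series, read in a functional assay on SW-620 cells (Homo sapiens) for cytotoxicity, read by MTT assay, with a stated time of 72 h; a higher number here means a weaker inhibitor, a lower number a stronger inhibitor. Compound 1 `COc1cccc(/C=C2\CCC/C(=C\c3ccc(OC)c(OC)c3)C2=O)c1` gives 3700 nM, compound 2 `COc1ccc(/C=C2\CCC/C(=C\c3ccc(OC)c(OC)c3)C2=O)cc1` gives 6600 nM, and compound 3 `COc1ccc(/C=C2\CCC/C(=C\c3ccc(Cl)cc3Cl)C2=O)cc1OC` gives 10300 nM. Compound 2 stands in the middle of these three numbers, and both of its measured steps, a 1.8-fold higher number from compound 1 to compound 2 (0.25 log units; within the scatter) and a 1.6-fold higher number from compound 2 to compound 3 (0.19 log units; within the scatter), stay within the scatter. Only a 2.8-fold higher number from compound 1 to compound 3 (0.44 log units; beyond the scatter) goes beyond it, and modestly.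

Compound 4 `COc1ccc(/C=C2\CCC/C(=C\c3ccc(OC)c(OC)c3)C2=O)cc1OC` comes from compound 2 by a single change, methoxy in place of hydrogen on an aromatic carbon. Going by the values given here, no measured step adds a group in this way, so the evidence is indirect. The nearest comparison is a 1.8-fold higher number from compound 1 to compound 2 (0.25 log units; within the scatter), which exchanges 3-methoxyphenyl for 4-methoxyphenyl on the ring that changes here. Replacing that ring with 2,4-dichlorophenyl gives a 1.6-fold higher number from compound 2 to compound 3 (0.19 log units; within the scatter), and the largest change seen on it is a 2.8-fold higher number from compound 1 to compound 3 (0.44 log units; beyond the scatter). On these small steps, no shift beyond the scatter is expected in this assay, in either direction. The estimated step is a 1.2-fold lower number from compound 2 to compound 4 (0.08 log units; within the scatter). For compound 4 the estimated value is 5500 nM, with an expected range of 2300 nM to 13000 nM.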

Compound 4, half-maximal inhibitory concentration: 4500 nM
For compound 4 the middle estimate is 1.2-fold (0.09 log units) above the measured one; low and high end bracket the measured number.
By their numbers in this assay, from the lowest: compounds 1, 4, 2 and 3 (each within the scatter of the next, the first and the last beyond it).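

Adding methoxy in place of hydrogen, on an aromatic carbon ortho to a methoxy group and meta to a large group, gives a 1.5-fold lower number from compound 2 to compound 4 (0.17 log units; within the scatter) in this assay. Going by these compounds alone, this is the first direct reading of an added group on this ring, as the earlier steps only exchanged one whole ring for another. The same kind of addition, starting from the other single-methoxy ring, gives a 1.2-fold higher number from compound 1 to compound 4 (0.09 log units; within the scatter) and also stays within the scatter, so compound 4 cannot be separated from either compound 1 or compound 2 in this assay, and a second methoxy on this ring has no readable effect here. No measurement in hand bears on why this is so.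

The compounds shown leave open whether anything other than methoxy on this aromatic carbon, such as an amine, a carboxylic acid or a longer alkoxy chain, would move the number beyond the scatter. They also leave open whether the same addition would read alike on the 2,4-dichlorophenyl ring of compound 3.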